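The compounds below may be only part of what the source reports. "The series", "measured", "known", "first", "only" and "open" are said of these compounds alone.

Series around the shared core of compound 1 `CC(C)(C)OC(=O)N1CCC(O[C@H]2CC[C@H](Oc3ccc(C#N)cc3)CC2)CC1` and compound 2 `C[C@@H](CF)OC(=O)N1CCC(O[C@H]2CC[C@H](Oc3cnc(S(C)(=O)=O)cn3)CC2)CC1`. In a functional assay on isolated protein for agonist activity at Glucose-dependent insulinotropic receptor (Rattus norvegicus), read by HTRF and cAMP accumulation (on this read-out lower numbers stand for an effect already at smaller amounts and higher numbers for an effect only at larger amounts of compound), compound 1 gives 45 nM, while compound 2 gives 356 nM, the higher of the two numbers and beyond the scatter. Compound 3 `CC(C)c1noc(CN2CCC(O[C@H]3CC[C@H](Oc4cnc(S(C)(=O)=O)cn4)CC3)CC2)n1` is not yet measured; it differs from compound 2 only in that (a group of 9 heavy atoms (6 carbon, 2 nitrogen, 1 oxygen; one five-membered aromatic ring with 3 hetero atoms) in place of a group of 7 heavy atoms (4 carbon, 2 oxygen, 1 fluorine; no ring), on an amine nitrogen in a ring). Within the data shown here, no measured pair shows this kind of change, so its effect is unknown here; a step in this assay of a 1.2-fold lower number from compound 2 to compound 3 (0.07 log units; within the scatter) is expected, within the scatter, in no clear direction. Compound 3 is estimated at 300 nM, with a range from 80 nM to 1200 nM.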

Compound 3, half-maximal effective concentration: 97.9 nM
Estimate against measurement, compound 3: 3.1-fold (0.49 log units) above; measured number inside the range.
By their numbers in this assay, from the lowest: compound 1; then compound 3; then compound 2.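

In this assay, placing (3-isopropyl-1,2,4-oxadiazol-5-yl)methyl on the amine nitrogen in the ring, in place of the open-chain, fluorine-bearing group of 7 heavy atoms, gives a 3.6-fold lower number from compound 2 to compound 3 (0.56 log units; beyond the scatter) and thus a modest gain. This position therefore accepts a five-membered aromatic ring with 3 hetero atoms, and the defined stereocentre of the group that leaves is not required for activity. Nothing measured here accounts for the step.

Still open, on these data alone, is whether the isopropyl matters, for example against a cyclopropyl on the same ring, and whether a benzyl on this nitrogen would serve equally.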